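From nitro to isopropyl on a weak inhibitor

This account rests on a few compounds, and the source may have more. Where it says the series, first, only, none or still open, it means among the compounds named here.

Compound 1 `Nc1ccccc1NC(=O)c1ccc(COc2ccc([N+](=O)[O-])cc2)cc1` gives > 32000 nM (a limit)
Compound 2 `O=C(/C=C/c1ccc(CN2CCc3ccccc32)cc1)NO` gives "not determined" (no result reported)
Compound 3 `Nc1ccccc1NC(=O)c1ccc(CN2CCc3cc(Br)ccc32)cc1` gives 7390 nM

In a functional assay on MGC-803 cells (Homo sapiens) for antiproliferative activity, read by CCK-8 assay, with a stated time of 72 h (a higher number here means a weaker inhibitor, a lower number a stronger inhibitor), compound 1 gives > 32000 nM and this is a limit of the assay, not a number. Compound 1 thus stands at the end of the scale, as the limit of > 32000 nM in this assay, at which 1 of the 3 values shown sits, shows. Compound 2 offers no result for comparison. Compound 4 `CC(C)c1ccc(OCc2ccc(C(=O)Nc3ccccc3N)cc2)cc1` keeps the core of compound 1 and carries isopropyl in place of nitro on an aromatic carbon, para to a large group (isopropyl in place of nitro on an aromatic carbon). Among the compounds with values here, no measured pair shows what this kind of change does, so the expectation is loose. Within the data shown here, compound 3 reaches a number at 7390 nM and is the only guide to where a measured value might fall. A moderate gain toward stronger inhibition is expected, and the estimated move is an at least 2.2-fold lower number from compound 1 to compound 4 (0.35 log units; beyond the scatter) with compound 4 possibly still stopping at the limit. For compound 4 the estimated value is 14000 nM with an expected range from 4500 nM to 40000 nM.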

Compound 4, half-maximal inhibitory concentration: > 32000 nM
Compound 4: no number, only a limit; the forecaster's own chance of this, stated with the estimate: 30%; at least 2.2-fold (0.35 log units) between middle value and limit.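

In this assay compound 4 gives > 32000 nM, a limit of the assay and not a number. Compound 1 and compound 4 therefore both stop at a limit, and no step between them can be read: the limit of > 32000 nM in this assay, at which 2 of the 4 values shown sit.

The compounds shown leave open what isopropyl in place of nitro on an aromatic carbon does to the activity.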